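The source may hold more compounds than are shown below. What is called first, only, known or untested is meant among the compounds shown, and "the series" means these compounds.

Compound 3 `O=C(NCc1ccc(CNS(=O)(=O)c2ccccc2)cc1)c1ccccc1Cl` gives the lowest of the three numbers in an assay on MDA-MB-231 cells for binding affinity to C-X-C chemokine receptor type 4 (Homo sapiens), read by immunofluorescence and microscopy, with stated times of 10 min and 30 min (on this read-out lower numbers stand for an effect already at smaller amounts and higher numbers for an effect only at larger amounts of compound), at 10 nM. Compound 1 `COc1ccc(C(=O)NCc2ccc(CNS(=O)(=O)c3ccc(C)cc3)cc2)cc1` gives 100 nM in this assay, and compound 2 `Cc1ccc(C(=O)NCc2ccc(CNS(=O)(=O)c3ccc(C)cc3)cc2)cc1` gives 1000 nM. Compound 4 `COc1ccccc1C(=O)NCc1ccc(CNS(=O)(=O)c2ccccc2)cc1` differs from compound 3 by methoxy in place of chloro on an aromatic carbon. Within the data shown here, no measured step exchanges chloro for methoxy; the only step available, a 10-fold higher number from compound 1 to compound 2 (1.00 log units; beyond the scatter), concerns methyl against methoxy rather than chloro against methoxy, and so bears only loosely on this change, although it shows a methoxy group carrying the lower of two numbers. Compound 4 is therefore expected to stay near compound 3, with a 3.0-fold higher number from compound 3 to compound 4 (0.48 log units; beyond the scatter) as the estimated step. The estimate for compound 4 is 30 nM, within a range from 5 nM to 200 nM.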

Compound 4, effective concentration (reported as EC, without a stated level of effect): 1 nM
For compound 4 the middle estimate is 30-fold (1.48 log units) above the measured one; the measured number lies below the stated range.
By their numbers in this assay, from the lowest: compound 4; then compound 3; then compound 1; then compound 2.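

In this assay, among these compounds, the change from 2-chlorophenyl to 2-methoxyphenyl gives a 10-fold lower number from compound 3 to compound 4 (1.00 log units; beyond the scatter), the first step here that sets methoxy against chloro and the first at this place, ortho to a large group. Methoxy now carries the lower number in both available steps, although the other step, a 10-fold higher number from compound 1 to compound 2 (1.00 log units; beyond the scatter), exchanges it for methyl rather than chloro. Nothing measured here accounts for the size of this step. Still open, going by these compounds, is how a hydroxy, ethoxy or dimethylamino group at this place would compare with methoxy.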